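The source may report more compounds than this note shows. Statements on the series, on what has been measured and on what is new or still open speak of the compounds shown alone.

Measured compounds, cytotoxicity read-out:

compound 1 `COc1ccccc1/C=C/C(=O)/C=C/c1ccc(OCc2cn(CCOc3cc(=O)oc4ccccc34)nn2)c(OC)c1` gives 11500 nM
compound 2 `COc1cc(/C=C/C(=O)/C=C/c2cc(OC)c(OC)c(OC)c2)ccc1OCc1cn(CCCOc2cc(=O)oc3ccccc23)nn1` gives 10600 nM
compound 3 `COc1ccc(/C=C/C(=O)/C=C/c2ccc(OCc3cn(CCOc4cc(=O)oc5ccccc45)nn3)c(OC)c2)cc1OC` gives 6780 nM

In a functional assay on COLO 205 cells (Homo sapiens) for cytotoxicity, read by sulforhodamine B assay, with a stated time of 48 h (on this read-out lower numbers stand for stronger inhibition and higher numbers for weaker inhibition), compound 3 gives 6780 nM, and this number sits together with those of compound 1 and compound 2: the gaps to both lie within the scatter, so no ordering among the three can be read from the data. Within the data shown here, the one step that joins two of them, a 1.7-fold lower number from compound 1 to compound 3 (0.23 log units; within the scatter), is itself within the scatter.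

Compound 4 `COc1cc(/C=C/C(=O)/C=C/c2cccc3ccccc23)ccc1OCc1cn(CCOc2cc(=O)oc3ccccc23)nn1` is the next member of the series. Relative to compound 3 the change is naphthalen-1-yl in place of 3,4-dimethoxyphenyl on a double-bonded chain carbon bound to a double-bonded chain carbon. Among the measured compounds shown here, only the step from compound 1 to compound 3 bears on it, and only loosely, as an exchange of the aryl group at the same chain position; it was a 1.7-fold lower number from compound 1 to compound 3 (0.23 log units; within the scatter). For the measured compounds named here, no measured pair removes both methoxy groups or brings in a second aromatic ring at this place. The expectation therefore rests on the narrow spread of the three numbers: the step is expected to be a 1.2-fold higher number from compound 3 to compound 4 (0.07 log units; within the scatter), without a change beyond the scatter. Compound 4 is estimated at 8000 nM, with a range from 2500 nM to 25000 nM.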

Compound 4, half-maximal inhibitory concentration: 9950 nM
Estimate against measurement, compound 4: 1.2-fold (0.09 log units) below; the range from low to high includes it.
By their numbers in this assay, from the lowest: compounds 3, 4, 2 and 1 (each within the scatter of the next).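

Notes on the aryl group on a double-bonded chain carbon bound to a double-bonded chain carbon: naphthalen-1-yl in place of 3,4-dimethoxyphenyl gives a 1.5-fold higher number from compound 3 to compound 4 (0.17 log units; within the scatter) and in place of 2-methoxyphenyl gives a 1.2-fold lower number from compound 1 to compound 4 (0.06 log units; within the scatter) in this assay at this place. Unlike the earlier step between two methoxy-bearing phenyl groups, these exchanges remove every methoxy group from this aryl group and bring in a second six-membered aromatic ring of carbon only. Neither exchange gives a change that can be read, so compounds 1, 3 and 4 show no dependence on these aryl groups.

As far as these compounds go, it remains open whether any group at this place moves the number beyond the scatter, for example a phenyl group carrying an amine or a carboxylic acid. No available evidence bears on why these numbers stay together.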